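The source may hold more compounds than are shown below. What is called first, only, known or untested is meant among the compounds shown, and "the series" means these compounds.

Measured so far:
Compound 1 `OC[C@H]1O[C@@H](n2cnc3c(NCc4ccc(Cl)c(Cl)c4)ncnc32)[C@H](O)[C@@H]1O` gives 10800 nM in a functional assay on K562 cells (Homo sapiens) for antiproliferative activity, with a stated time of 72 h; on this read-out higher numbers stand for weaker inhibition and lower numbers for stronger inhibition.
Compound 2 `COc1cc(CNc2ncnc3c2ncn3[C@@H]2O[C@H](CO)[C@@H](O)[C@H]2O)cc(OC)c1O` gives > 166000 nM, a limit of the assay.
Compound 3 `COc1cc(O)cc(OC)c1CNc1ncnc2c1ncn2[C@@H]1O[C@H](CO)[C@@H](O)[C@H]1O` gives > 166000 nM, a limit of the assay.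

Compound 1 is the only one of the three with a number in this assay; the other two values are the limit of > 166000 nM in this assay, at which 2 of the 3 values shown sit. Compound 4 `Cc1cccc(CNc2ncnc3c2ncn3[C@@H]2O[C@H](CO)[C@@H](O)[C@H]2O)c1O` has not been measured. It differs from compound 1 by 2-hydroxy-3-methylphenyl in place of 3,4-dichlorophenyl on a saturated chain carbon bound to a nitrogen on an aromatic ring. Within the data shown here, no measured pair differs in a single place, so the size of this step is not known from a measurement. Compounds 2 and 3, which also carry an oxygen-bearing benzyl group rather than the dichlorophenyl, both sit at the limit, so a step toward weaker inhibition beyond the usual scatter is expected. Compound 4 is estimated at 90000 nM, between 25000 nM and 300000 nM. The expected step of an 8.3-fold higher number from compound 1 to compound 4 (0.92 log units; beyond the scatter) could well end as a limit rather than a number.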

Compound 4, half-maximal inhibitory concentration: 18000 nM
The estimate for compound 4 lay 5.0-fold (0.70 log units) above the measured number, and the stated range ends above it.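

In this assay, replacing the 3,4-dichlorophenyl with 2-hydroxy-3-methylphenyl on the saturated chain carbon gives a 1.7-fold higher number from compound 1 to compound 4 (0.22 log units; within the scatter). A ring without chlorine can therefore hold a measurable value at this place, and one that cannot be told apart from that of the dichlorinated ring. Compounds 2 and 3 remain at a limit of the assay, not a number: the limit of > 166000 nM in this assay, at which 2 of the 4 values shown sit.

The compounds shown leave open whether the hydroxy or the methyl group of compound 4 matters more. They also leave open how a ring carrying an amine or a carboxylic acid would compare at this place.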